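Methyl to cyano in the bioavailability series

A few compounds are considered here, and "the series" means these few. Any claim that something is new, unique, unknown or untested is made for them only; others in the source may bear on it.

Values from an ADME assay on the whole organism for pharmacokinetics, with Rattus norvegicus as the target (a higher number here means that a larger share of the oral dose reaches the circulation, a lower number that a smaller share of the oral dose reaches the circulation), for the measured compounds:
- compound 1 `COc1nc2ccc(Br)cc2cc1[C@@H](c1ccc(N(C)C)nc1)[C@@](O)(CCN(C)C)c1cccc(F)c1` gives 45%
- compound 2 `COc1nc2ccc(Br)cc2cc1[C@@H](c1ccnc(OC)c1OC)[C@@](O)(CCN(C)C)c1cccc(C)c1` gives 40%
- compound 3 `CCSc1ccc([C@H](c2cc3cc(Br)ccc3nc2OC)[C@@](O)(CCN(C)C)c2cccc(F)c2)cn1` gives 30%

Compound 2 at 40% lies within the scatter of both other compounds, so it holds no rank of its own among them. Compound 4 `COc1nc2ccc(Br)cc2cc1[C@@H](c1ccnc(OC)c1OC)[C@@](O)(CCN(C)C)c1cccc(C#N)c1` awaits measurement. Against compound 2 its change is cyano in place of methyl on an aromatic carbon. For the measured compounds named here, the one measured step (a number 15 percentage points lower from compound 1 to compound 3 (beyond the scatter)) exchanges other groups, ethylsulfanyl in place of dimethylamino, so it indicates only the size a single exchange reached in this small set. Going by the values given here, no measured step in this assay involves methyl or cyano, which leaves the direction without support from the data, and no step beyond the scatter is expected. The estimated change (a number 5 percentage points lower from compound 2 to compound 4 (within the scatter)) is therefore kept small. Compound 4 is estimated at 35% (range 18% to 52%).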

Compound 4, oral bioavailability: 68%
Compound 4: the middle estimate sits 33 percentage points below what was measured; measured number above the stated range.
By their numbers in this assay, from the lowest: compounds 3, 2 and 1 (each within the scatter of the next, the first and the last beyond it); then compound 4.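

In this assay, the exchange of 3-methylphenyl for 3-cyanophenyl gives a number 28 percentage points higher from compound 2 to compound 4 (beyond the scatter). For the compounds shown here, this shows that oral bioavailability responds to a single exchange on an aromatic carbon of the six-membered aromatic ring of carbon only, meta to a large group, which the earlier compounds could not show, since the one step among them lies elsewhere. No measurement at hand explains the size of this step.

From the compounds shown here alone, it remains open whether the step is particular to cyano or would also appear with another group at this place, such as chloro, trifluoromethyl or a primary amide. Going by these compounds, it is equally open whether cyano would give a step of like size in place of the fluoro group of compound 1 or compound 3.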